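Dichlorophenyl isomer step in the series

This account rests on a few compounds, and the source may have more. Where it says the series, first, only, none or still open, it means among the compounds named here.

- compound 1 `O=C(/C=C/c1ccccc1)Nc1cc2ncnc(Nc3ccc(F)c(Cl)c3)c2s1` gives 6670 nM
- compound 2 `O=C(/C=C/c1ccccc1)Nc1cc2ncnc(Nc3cc(Cl)cc(Cl)c3)c2s1` gives 12500 nM

In a functional assay on A549 cells (Homo sapiens) for antiproliferative activity, read by MTT assay, with a stated time of 48 h (a higher number here means a weaker inhibitor, a lower number a stronger inhibitor), compound 2, at 12500 nM, stands level with compound 1, at 6670 nM. Compound 3 `O=C(/C=C/c1ccccc1)Nc1cc2ncnc(Nc3ccc(Cl)c(Cl)c3)c2s1` follows with 3,4-dichlorophenyl in place of 3,5-dichlorophenyl on a nitrogen on an aromatic ring. Among the measured compounds shown here, the sole measured step, a 1.9-fold higher number from compound 1 to compound 2 (0.27 log units; within the scatter), changed the same group at the same place, so no step beyond the scatter is expected in this assay. The estimated step is a 1.6-fold lower number from compound 2 to compound 3 (0.19 log units; within the scatter). The estimate for compound 3 is 8000 nM, with an expected range of 3500 nM to 17000 nM.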

Compound 3, half-maximal inhibitory concentration: 19500 nM
Compound 3: middle estimate off by 2.4-fold (0.39 log units), on the low side, and the stated range ends below it.
By their numbers in this assay, from the lowest: compounds 1, 2 and 3 (each within the scatter of the next, the first and the last beyond it).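

In this assay 3,4-dichlorophenyl in place of 3,5-dichlorophenyl on the nitrogen gives a 1.6-fold higher number from compound 2 to compound 3 (0.19 log units; within the scatter) and so does not separate these two dichlorophenyl isomers. Chloro in place of fluoro on an aromatic carbon gives a 2.9-fold higher number from compound 1 to compound 3 (0.47 log units; beyond the scatter) and is the first step in this set to pass the scatter, though only modestly. Nothing at hand bears on the cause of either step.

The compounds shown leave open how a methoxy group or an amine in place of chloro on this phenyl ring would read in this assay and whether the chloro for fluoro step holds with other neighbouring groups.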